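A Third Methoxy Group on the Carbonyl-Side Ring

The compounds below may be only part of what the source reports. "The series", "measured", "known", "first", "only" and "open" are said of these compounds alone.

Compound 1, `COc1cc(-c2cc(/C=C/C(=O)c3ccc(Cl)c(Cl)c3)[nH]n2)cc(OC)c1OC`: > 100000 nM
Compound 2, `COc1ccc(C(=O)/C=C/c2cc(-c3cc(OC)c(OC)c(OC)c3)n[nH]2)cc1OC`: 5750 nM

Of the compounds shown here, two with a shared core have been measured in a functional assay on OVCAR-5 cells (Homo sapiens) for inhibition, read by sulforhodamine B assay, with a stated time of 48 h; a higher number here means that more compound is tolerated, a lower number that less compound is tolerated. For compound 1 only a limit is reported, > 100000 nM, which is the limit of > 100000 nM in this assay, at which 1 of the 2 values shown sits. Among the measured compounds shown here, compound 2 is the only compound with a number in this assay, giving 5750 nM. The value of compound 1 is only a limit, so compound 2 cannot be ranked against it beyond the step itself.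

That one measured step, an at least 17-fold lower number from compound 1 to compound 2 (1.24 log units; beyond the scatter), exchanges the entire ring on the carbonyl carbon and starts from a limit, so it does not speak directly to a smaller change on that ring.

Compound 3, `COc1cc(C(=O)/C=C/c2cc(-c3cc(OC)c(OC)c(OC)c3)n[nH]2)cc(OC)c1OC`, differs from compound 2 by methoxy in place of hydrogen on an aromatic carbon. For the measured compounds named here, no measured step covers the addition of a single methoxy group, so the expected step is a 1.2-fold lower number from compound 2 to compound 3 (0.06 log units; within the scatter), within the scatter, with a wide range to reflect the lack of a comparable step. Compound 3 is therefore estimated at 5000 nM, between 1500 nM and 17000 nM.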

Compound 3, concentration lethal to 50% of the cells: 5920 nM
Estimate against measurement, compound 3: 1.2-fold (0.07 log units) below, within the range that was stated.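

In this assay, putting methoxy in place of hydrogen on the carbonyl-side ring, on an aromatic carbon ortho to a methoxy group and meta to a large group, gives a 1.0-fold higher number from compound 2 to compound 3 (0.01 log units; within the scatter) and so leaves the read-out within the scatter. The earlier step exchanged the entire ring and started from a limit, whereas this one changes a single group on a ring that already carries methoxy groups, and it shows that this position takes a further methoxy group without a change that can be told from the scatter. Nothing measured among these compounds gives a reason for this result.

Whether an amine, a carboxylic acid or a longer chain such as ethoxy on this same aromatic carbon would also leave the number within the scatter stays open, since methoxy is the only group shown there. From the compounds shown here alone, compound 1 gives > 100000 nM as a limit only, so how much of the earlier step belongs to either chlorine, or to either methoxy group that replaced it, also stays open.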